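The source may hold more compounds than are shown below. What is called first, only, known or untested is meant among the compounds shown, and "the series" means these compounds.

Measured compounds in a functional assay on DU-145 cells (Homo sapiens) for cytotoxicity, read by trypan blue exclusion, with a stated time of 96 h; on this read-out lower numbers stand for stronger inhibition and higher numbers for weaker inhibition:
- compound 1, `COC(=O)CNc1cc(NS(=O)(=O)/C=C/c2c(OC)cc(OC)cc2OC)ccc1OC`: 350 nM
- compound 2, `COC(=O)C(C)Nc1cc(NS(=O)(=O)/C=C/c2c(OC)cc(OC)cc2OC)ccc1OC`: 100 nM
- compound 3, `COc1cc(OC)c(/C=C/S(=O)(=O)Nc2ccc(OC)c(NCC(=O)O)c2)c(OC)c1`: 400 nM

Compound 1 and compound 3 share a core; the difference between them is hydrogen in place of methyl on an oxygen next to a carbonyl group, and in this assay it gives a 1.1-fold higher number from compound 1 to compound 3 (0.06 log units; within the scatter), so the two numbers cannot be told apart. Compound 2 and compound 3 stand further apart, with a 4.0-fold higher number from compound 2 to compound 3 (0.60 log units; beyond the scatter).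

Within the ester pair, the change methyl in place of hydrogen on a saturated chain carbon bound to a carbonyl carbon and a nitrogen on an aromatic ring produced a 3.5-fold lower number from compound 1 to compound 2 (0.54 log units; beyond the scatter), a step clearly outside the scatter.

Compound 4, `COc1cc(OC)c(/C=C/S(=O)(=O)Nc2ccc(OC)c(NC(C)C(=O)O)c2)c(OC)c1`, has not been measured. It is related to compound 3 by methyl in place of hydrogen on a saturated chain carbon bound to a carbonyl carbon and a nitrogen on an aromatic ring, which is the same change as that from compound 1 to compound 2, made at the same place; the two cores differ only as described for compound 1 and compound 3. Within the data shown here, the step from compound 3 to compound 4 is therefore expected to resemble the earlier one, because a 3.5-fold lower number from compound 1 to compound 2 (0.54 log units; beyond the scatter) stands as the only measured instance of this change and because a 1.1-fold higher number from compound 1 to compound 3 (0.06 log units; within the scatter) shows the two cores behave alike in this assay. The expected step is a 3.3-fold lower number from compound 3 to compound 4 (0.52 log units; beyond the scatter). Resting on a single precedent, the range is kept wide. Compound 4 is accordingly estimated at 120 nM, with the likely interval from 50 nM to 300 nM.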

Compound 4, half-maximal inhibitory concentration in the DU-145 assay: 40 nM
Beside the measured number, compound 4's estimate is 3.0-fold (0.48 log units) above it; the whole stated range lies above it.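

In the DU-145 assay methyl in place of hydrogen on the saturated chain carbon lowers the number on both cores, but a 10-fold lower number from compound 3 to compound 4 (1.00 log units; beyond the scatter) is a larger step than a 3.5-fold lower number from compound 1 to compound 2 (0.54 log units; beyond the scatter), so the direction carries over and the size does not: the same change on two cores in the DU-145 assay, a 3.5-fold lower number (0.54 log units; beyond the scatter) from compound 1 to compound 2 and a 10-fold lower number (1.00 log units; beyond the scatter) from compound 3 to compound 4, 2.9-fold (0.46 log units) apart, beyond the scatter of two such steps In the DU-145 assay the replacement of the ester methyl by hydrogen likewise depends on its setting, with a 2.5-fold lower number from compound 2 to compound 4 (0.40 log units; beyond the scatter) on the methyl-bearing chain and no separable change on the unbranched one: the same change on two cores in the DU-145 assay, a 1.1-fold higher number (0.06 log units; within the scatter) from compound 1 to compound 3 and a 2.5-fold lower number (0.40 log units; beyond the scatter) from compound 2 to compound 4, 2.9-fold (0.46 log units) apart, beyond the scatter of two such steps The two changes together give, in the DU-145 assay, an 8.8-fold lower number from compound 1 to compound 4 (0.94 log units; beyond the scatter), but this rests on a single square of four compounds, which shows that the changes do not add up simply and does not show why. In a physicochemical assay for solubility (a higher number here means a more soluble compound, a lower number a less soluble compound), compound 3 gives 10000 ug/mL and compound 4 gives 10000 ug/mL. Among these compounds, in the physicochemical assay the one available comparison gives no change at the digits printed from compound 3 to compound 4 (within the scatter), so solubility does not separate this pair.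

Still open, from the compounds shown here alone, is whether a longer chain, such as ethyl in place of the methyl, extends the gain seen with compound 4 or reverses it. Also open, going by these compounds, is whether an amide in place of the carboxylic acid or the methyl ester behaves like either of these cores.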